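Dichloro phenoxy variant in the cytotoxicity series

The compounds below may be only part of what the source reports. "The series", "measured", "known", "first", "only" and "open" are said of these compounds alone.

For the measured compounds named here, compound 2 `Cc1cn(C2CCN(Cc3cncc(Oc4ccccc4)c3)CC2)c(=O)[nH]c1=O` is the only member of this set with a result in an ADME assay on MRC5 cells (Homo sapiens) for cytotoxicity, read by fluorescence and resazurin assay, with a stated time of 3 days; on this read-out higher numbers stand for weaker inhibition and lower numbers for stronger inhibition. In this assay compound 2 gives > 64000 nM, which is a limit of the assay rather than a number, as recorded in the limit of > 64000 nM in this assay, at which 1 of the 2 values shown sits. In this assay compound 1 `Cc1cn(C2CCN(Cc3cccc(Oc4ccccc4)c3)CC2)c(=O)[nH]c1=O` gives "not determined" (no result reported). Compound 3 `Cc1cn(C2CCN(Cc3cncc(Oc4cc(Cl)cc(Cl)c4)c3)CC2)c(=O)[nH]c1=O` carries 3,5-dichlorophenyl in place of phenyl on an oxygen on an aromatic ring. Going by the values given here, no step between measured compounds is available, so the size of this change rests on the single limit. The step expected in this assay is an at least 1.2-fold lower number from compound 2 to compound 3 (0.10 log units; that floor lies within the scatter), no larger than the usual scatter. Compound 3 is estimated at 50000 nM, with a range from 16000 nM to 120000 nM.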

Compound 3, half-maximal inhibitory concentration: > 64000 nM
Compound 3 was reported as a limit; the forecaster's own chance of this, stated with the estimate: 60%; middle value at least 1.2-fold (0.10 log units) away from the limit.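

Compound 2 and compound 3 are both reported only as a limit in this assay, so no step can be read between them. The compounds shown leave open whether 3,5-dichlorophenyl in place of phenyl changes this read-out at all.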